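The source may hold more compounds than are shown below. What is called first, only, known or untested is meant among the compounds shown, and "the series" means these compounds.

Compound 1 `CCCCCn1ccc2c(CCC)c(OCCCCOc3ccc(-c4nn[nH]n4)cc3)ccc21`: 598 nM; compound 2 `CCCc1c(OCCCCOc2ccc(-c3nn[nH]n3)cc2)ccc2c1ccn2CC(C)C`: 765 nM.

Both numbers come from a functional assay for binding affinity to metabotropic glutamate receptor 2 (Homo sapiens), read by GTPgammaS binding, with a stated time of 1 h, at 30 degrees C; a higher number here means that more compound is needed for the effect, a lower number that less compound is needed. Among the two measured compounds, compound 2 gives 765 nM, and its only neighbour, compound 1, lies within the scatter of it, as the step of a 1.3-fold higher number from compound 1 to compound 2 (0.11 log units; within the scatter) shows. Compound 3 `CCCc1c(OCCCCOc2ccc(-c3nn[nH]n3)cc2)ccc2c1ccn2CC1CCCCC1` differs from compound 2 by cyclohexyl in place of isopropyl on a saturated chain carbon bound to an aromatic nitrogen. Within the data shown here, that single measured step is the only one bearing on this change, and it stayed within the scatter, so for compound 3 a step of a 1.1-fold lower number from compound 2 to compound 3 (0.04 log units; within the scatter) reaching no further than the scatter is expected. Compound 3 is therefore estimated at 700 nM, with a range from 250 nM to 2000 nM.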

Compound 3, half-maximal effective concentration: 228 nM
Beside the measured number, compound 3's estimate is 3.1-fold (0.49 log units) above it, outside the stated range (below it).
By their numbers in this assay, from the lowest: compound 3; then compounds 1 and 2 (each within the scatter of the next).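

On the saturated chain carbon bound to an aromatic nitrogen, butyl and isopropyl stayed within the scatter of each other, but cyclohexyl shows that this position can respond: a 3.4-fold lower number from compound 2 to compound 3 (0.53 log units; beyond the scatter), and a 2.6-fold lower number from compound 1 to compound 3 (0.42 log units; beyond the scatter). Both steps are modest, and each puts a six-membered carbon ring in place of an open chain, so the ring itself cannot be separated from the added carbons. Nothing measured here explains this shift.

Still open, from the compounds shown here alone, is whether cyclopentyl, a longer chain such as hexyl, or a ring carrying an amine would keep the lower number at this place.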